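The compounds below may be only part of what the source reports. "The series", "measured", "known", "first", "only" and "open" are said of these compounds alone.

Measured in a functional assay on CWR22R cells (Homo sapiens) for antiproliferative activity, read by propidium iodide staining, with a stated time of 96 h; on this read-out higher numbers stand for weaker inhibition and lower numbers for stronger inhibition:

Compound 1 `CC(O)(COc1cccc(S(F)(F)(F)(F)F)c1)C(=O)Nc1ccc(C(F)(F)F)cc1` gives 15800 nM.
Compound 2 `CC(O)(COc1cccc(S(F)(F)(F)(F)F)c1)C(=O)Nc1cc(C(F)(F)F)cc(C(F)(F)F)c1` gives 2300 nM.
Compound 3 `CC(O)(COc1cccc(C(F)(F)C(F)(F)F)c1)C(=O)Nc1ccc(C(F)(F)F)cc1` gives 3600 nM.

Compound 3 differs from compound 1 by a group of 7 heavy atoms (2 carbon, 5 fluorine; no ring) in place of a group of 6 heavy atoms (5 fluorine, 1 sulfur; no ring), on an aromatic carbon; this change gave a 4.4-fold lower number from compound 1 to compound 3 (0.64 log units; beyond the scatter). The difference between the cores of compound 1 and compound 2 is not broken down here. Compound 2 and compound 3 show values close to each other.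

Compound 4 `CC(O)(COc1cccc(C(F)(F)C(F)(F)F)c1)C(=O)Nc1cc(C(F)(F)F)cc(C(F)(F)F)c1` differs from compound 2 by a group of 7 heavy atoms (2 carbon, 5 fluorine; no ring) in place of a group of 6 heavy atoms (5 fluorine, 1 sulfur; no ring), on an aromatic carbon, the same change as from compound 1 to compound 3. Going by the values given here, only one measured example of this change exists, so the expectation rests on it alone. In this assay compound 4 is expected to move by a 3.8-fold lower number from compound 2 to compound 4 (0.58 log units; beyond the scatter), a step in line with a 4.4-fold lower number from compound 1 to compound 3 (0.64 log units; beyond the scatter) but with wide uncertainty. The expected value for compound 4 is 600 nM, estimated between 250 nM and 1500 nM.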

Compound 4, half-maximal inhibitory concentration: 4100 nM
Compound 4: middle estimate off by 6.8-fold (0.83 log units), on the low side, outside the stated range (above it).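

On the core of compound 2, placing 1,1,2,2,2-pentafluoroethyl where the group of five fluorine atoms and one sulfur stood gives a 1.8-fold higher number from compound 2 to compound 4 (0.25 log units; within the scatter) in this assay. The step read on the core of compound 1 therefore does not carry over to this core: the same change on two cores in this assay, a 4.4-fold lower number (0.64 log units; beyond the scatter) from compound 1 to compound 3 and a 1.8-fold higher number (0.25 log units; within the scatter) from compound 2 to compound 4, 7.8-fold (0.89 log units) apart, beyond the scatter of two such steps

With a single pair on each core, this shows that the outcome of the change differs between these two cores, but not which feature of the cores lies behind the difference or what a third core would give.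

Still open, as far as these compounds go, is whether a nitrile or a longer perfluorinated chain on the same aromatic carbon would also give steps that differ between the two cores.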